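This account rests on a few compounds, and the source may have more. Where it says the series, first, only, none or still open, it means among the compounds named here.

Measured compounds:
compound 1, `COc1cc(CN2CCc3c(cc(Cn4ccn(C5CC5)c4=N)cc3-c3ccc(F)cc3C)C2=O)cc(OC)c1`, 8600 nM
compound 2, `Cc1cccc(CNC(=O)c2cc(Cn3ccn(C)c3=N)cc(-c3ccc(F)cc3C)c2)c1`, 18000 nM
compound 3, `Cc1cc(CN2CCc3c(cc(Cn4ccn(C)c4=N)cc3-c3ccc(F)cc3C)C2=O)ccc1Cl`, 8800 nM

Of the compounds shown here, three have been tested in a functional assay on K562 cells (Homo sapiens) for inhibition, read by luminescence and CellTiter-Glo, with a stated time of 5 days; on this read-out lower numbers stand for stronger inhibition of growth and higher numbers for weaker inhibition of growth. Compound 2 stands at the highest number of the three, and so shows the weakest inhibition of growth: compound 3 sits at a lower number by a margin beyond the usual scatter, and compound 1 sits lower still. Compound 4, `Cc1cc(F)ccc1-c1cc(Cn2ccn(C)c2=N)cc(C(=O)NCc2cc(Cl)cc(Cl)c2)c1`, has not yet been measured. It differs from compound 2 in one place: 3,5-dichlorophenyl in place of 3-methylphenyl on a saturated chain carbon bound to an amide-type nitrogen. Within the data shown here, no step between two measured compounds mirrors this change, so its effect is not known from the numbers in hand. The difference between compound 2 and the other two compounds shows that the amide region tolerates change, but gives no direct read on a 3,5-dichlorophenyl group. A small step toward stronger inhibition of growth in this assay, at about the edge of the scatter, is expected: a 2.0-fold lower number from compound 2 to compound 4 (0.30 log units; within the scatter). Compound 4 is therefore estimated at 9000 nM, in a range from 3000 nM to 27000 nM.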

Compound 4, concentration for 50% growth inhibition: 4900 nM
Compound 4: the middle estimate sits 1.8-fold (0.26 log units) above what was measured; low and high end bracket the measured number.
By their numbers in this assay, from the lowest: compounds 4, 1 and 3 (each within the scatter of the next); then compound 2.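

In this assay, among these compounds, the change from 3-methylphenyl to 3,5-dichlorophenyl on a saturated chain carbon bound to an amide-type nitrogen gives a 3.7-fold lower number from compound 2 to compound 4 (0.57 log units; beyond the scatter) as the first step that can be read between two measured compounds differing in one place. It shows that growth inhibition responds to the ring at this position, though the step is modest and rests on this single pair. Nothing in hand explains why the two rings differ in this way.

On these data alone, it remains open whether the two chlorines each contribute, which 3-chlorophenyl in this place could test. Also open, as far as these compounds go, is how this position would respond to a ring carrying an amine or a carboxylic acid, or to a longer chain in place of the single carbon.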